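Replacing 1H-indazol-3-yl on a compound measured only as a limit

The source may report more compounds than this note shows. Statements on the series, on what has been measured and on what is new or still open speak of the compounds shown alone.

In an ADME assay on MT4 cells (Homo sapiens) for cytotoxicity, read by MTT assay (a lower number here means that less compound is tolerated, a higher number that more compound is tolerated), compound 2 `Cc1cc(C)cc(S(=O)(=O)c2c(C(=O)NCc3n[nH]c4ccccc34)[nH]c3ccc(Cl)cc23)c1` gives > 50700 nM, which is a limit of the assay and not a number. Compound 1 `Cc1cc(C)cc(S(=O)(=O)c2c(C(=O)NCc3cccc(F)c3F)[nH]c3ccc(Cl)cc23)c1` gives > 51100 nM, which is also a limit.

Compound 3 `Cc1cc(C)cc(S(=O)(=O)c2c(C(=O)NCC(=O)NC(C)c3ccccc3F)[nH]c3ccc(Cl)cc23)c1` carries (1-(2-fluorophenyl)ethyl)carbamoyl in place of 1H-indazol-3-yl on a saturated chain carbon bound to an amide-type nitrogen.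

Among the compounds with values here, only one measured change touches this place, a step that the two limits leave unreadable from compound 1 to compound 2, and it offers no size to carry over. With no measured size to build on, the expectation in this assay is for no step beyond the scatter, in either direction. The expected step is an at least 1.0-fold lower number from compound 2 to compound 3 (0.00 log units; that floor lies within the scatter). For compound 3 the estimated value is 50000 nM, with an expected range from 18000 nM to 55000 nM.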

Compound 3, half-maximal cytotoxic concentration: 23000 nM
Estimate against measurement, compound 3: 2.2-fold (0.34 log units) above; the range from low to high includes it.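

In this assay, within the data shown here, compound 3 gives the first real number at this place, on a saturated chain carbon bound to an amide-type nitrogen, so a change here can now be seen to matter: the steps are an at least 2.2-fold lower number from compound 2 to compound 3 (0.34 log units; beyond the scatter) and an at least 2.2-fold lower number from compound 1 to compound 3 (0.34 log units; beyond the scatter). The true step from compound 2 may be larger, because compound 2 stands at a limit and not at a number: the limit of > 50700 nM in this assay, at which 1 of the 3 values shown sits. The same holds for the step from compound 1, because compound 1 also stands at a limit: the limit of > 51100 nM in this assay, at which 1 of the 3 values shown sits.

The entering (1-(2-fluorophenyl)ethyl)carbamoyl group differs from both earlier groups in several parts at once, so the compounds shown do not tell which part goes with the lower number. A simple amine or a carboxylic acid at this place could help separate those parts.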